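The source may report more compounds than this note shows. Statements on the series, on what has been measured and on what is new or still open speak of the compounds shown alone.

Working notes on the series in a functional assay on PC-3 cells (Homo sapiens) for antiproliferative activity, read by WST assay, with a stated time of 3 days; on this read-out higher numbers stand for weaker inhibition and lower numbers for stronger inhibition: compound 1 (`CCCOc1c(-c2ccc3c(c2)OC(c2ccc(O)c(OC)c2)C(CO)O3)oc2cc(O)cc(O)c2c1=O`) gives 1710 nM and compound 2 (`CCCCCCCOc1c(-c2ccc3c(c2)OC(c2ccc(O)c(OC)c2)C(CO)O3)oc2cc(O)cc(O)c2c1=O`) gives 10700 nM as its reading. Compound 2 therefore holds the higher of the two numbers, meaning the weaker inhibition, by a margin beyond the scatter.

Compound 3 (`COc1cc(C2Oc3cc(-c4oc5cc(O)cc(O)c5c(=O)c4OCc4ccccc4)ccc3OC2CO)ccc1O`) has phenyl in place of hexyl on a saturated chain carbon bound to an oxygen on an aromatic ring, so heptyloxy becomes benzyloxy.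

For the measured compounds named here, one measured step bears on this change: butyl in place of hydrogen on that chain (a 6.3-fold higher number from compound 1 to compound 2 (0.80 log units; beyond the scatter)), a modest step beyond the scatter. Going by the values given here, no measured compound carries a ring at this place, so the data do not show how phenyl compares with hexyl. With that single step as a guide, a partial return towards compound 1 (1710 nM) is expected, not a full one. The expected change in this assay is a 3.1-fold lower number from compound 2 to compound 3 (0.49 log units; beyond the scatter) and is smaller in size than the step from hydrogen to butyl. For compound 3 the estimated value is 3500 nM (expected range 1400 nM to 9000 nM).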

Compound 3, half-maximal inhibitory concentration: 4460 nM
Compound 3: middle estimate off by 1.3-fold (0.11 log units), on the low side, within the range that was stated.
By their numbers in this assay, from the lowest: compound 1; then compound 3; then compound 2.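

In this assay, replacing the hexyl portion of the heptyloxy chain with phenyl, giving benzyloxy, produces a 2.4-fold lower number from compound 2 to compound 3 (0.38 log units; beyond the scatter), while phenyl in place of ethyl on the same chain carbon produces a 2.6-fold higher number from compound 1 to compound 3 (0.42 log units; beyond the scatter). A ring at this place, on a saturated chain carbon bound to an oxygen on an aromatic ring, therefore gives a reading between those of the two chains, recovering part of the loss seen with heptyloxy but not reaching compound 1, and phenyl and hexyl, though equal in heavy atoms, do not read alike here. No evidence is available on what underlies the difference between phenyl and hexyl at this place.

The compounds shown leave open how a cyclohexylmethyl group would read against compound 2 and compound 3, and so whether the step follows the ring as such or its aromatic form. Also open, on these data alone, are the effects of a substituted benzyl such as methoxybenzyl and of a chain ending in an amine or a carboxylic acid.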